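This account rests on a few compounds, and the source may have more. Where it says the series, first, only, none or still open, it means among the compounds named here.

Of the compounds shown here, three built on a shared core have been measured in an ADME assay on NIH3T3 cells (Mus musculus) for cytotoxicity, read by MTT assay, with a stated time of 24 h; on this read-out higher numbers stand for weaker inhibition and lower numbers for stronger inhibition. Compound 1 `COc1ccc(N2CCN(CC(=O)N3CCN(c4nnc(-c5ccccc5)c(-c5ccccc5)n4)CC3)CC2)cc1` reaches only a limit of the assay, > 910000 nM. Compound 2 `Cc1ccc(-c2nnc(N3CCN(C(=O)CN4CCN(c5cccc(Cl)c5)CC4)CC3)nc2-c2ccc(C)cc2)cc1` gives 859000 nM. Compound 3 `COc1ccc(-c2nnc(N3CCN(C(=O)CN4CCN(c5ccccc5Cl)CC4)CC3)nc2-c2ccc(OC)cc2)cc1` likewise reaches only a limit of the assay, > 814000 nM. On the numbers shown, compound 3 thus stands at the limit of > 814000 nM in this assay, at which 1 of the 3 values shown sits. Compound 1 also sits at a limit, (the limit of > 910000 nM in this assay, at which 1 of the 3 values shown sits). Compound 2 lies close to the same region, within the scatter of those limits.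

Compound 4 `COc1ccc(-c2nnc(N3CCN(C(=O)CN4CCN(c5ccc([N+](=O)[O-])cc5)CC4)CC3)nc2-c2ccc(OC)cc2)cc1` has not yet been measured. It differs from compound 3 by 4-nitrophenyl in place of 2-chlorophenyl on an amine nitrogen in a ring. No step between two measured compounds is shown, so the data give no direct indication of how this exchange moves the read-out. Since compound 1, compound 2 and compound 3 all lie at or near the top of what this assay reports, compound 4 is expected to remain there as well. For compound 4 the expected step is a step that the limit leaves unreadable from compound 3 to compound 4, none beyond the scatter. Compound 4 is estimated at 850000 nM, between 600000 nM and 1200000 nM.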

Compound 4, half-maximal inhibitory concentration: > 801000 nM
Compound 4: a limit, no number; the forecaster's own chance of this, stated with the estimate: 85%; the middle value does not contradict the limit.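

Compound 3 and compound 4 both give only a limit in this assay, not a number, and the step between them cannot be read. The compounds shown leave open whether 4-nitrophenyl in place of 2-chlorophenyl on an amine nitrogen in a ring moves this read-out at all.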